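The compounds below may be only part of what the source reports. "The series", "measured", "known", "first", "only" and "open" are said of these compounds alone.

Working notes on the series. The shared core of compound 1 `Cc1nc(N)sc1CCCN/C(N)=N/C(=O)N[C@@H](C)c1ccccc1` carries a 1-phenylethyl group on the amide-type nitrogen; in a functional assay on Right cardiac atrium for agonist activity at histamine H2 receptor (Cavia porcellus), with a stated time of 30 min, in the presence of a further agent that is not named here (a higher number here means that more compound is needed for the effect, a lower number that less compound is needed), compound 1 gives 23.4 nM, the lowest of the three numbers recorded. Compound 2 `Cc1nc(N)sc1CCCN/C(N)=N/C(=S)N[C@@H](C)c1ccccc1`, in which the carbonyl of the urea is replaced by a thiocarbonyl, gives 224 nM in this assay, a number beyond the scatter above that of compound 1. Compound 3 `Cc1nc(N)sc1CCCN/C(N)=N/C(=O)NC(C)c1ccc(OC(F)(F)F)cc1`, which bears a trifluoromethoxy group on the aromatic ring and has no defined stereocentre, gives 724 nM in this assay, the highest number of the three. Within the data shown here, no single-point step between measured compounds is available, so the spread seen here is only what these three values show.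

Compound 4 `Cc1nc(N)sc1CCCN/C(N)=N/C(=O)NC(C)c1cccs1` differs from compound 1 by 1-(thiophen-2-yl)ethyl in place of 1-phenylethyl on an amide-type nitrogen. Neither compound 2 nor compound 3 informs this particular exchange, so the expectation rests on the closeness of the two aryl groups in size and shape. A step of no more than modest size is expected, a 1.5-fold higher number from compound 1 to compound 4 (0.17 log units; within the scatter), most likely within the scatter or slightly toward a higher number. Compound 4 is therefore estimated at 35 nM in this assay, with a range from 12 nM to 120 nM.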

Compound 4, half-maximal effective concentration: 10 nM
For compound 4 the middle estimate is 3.5-fold (0.54 log units) above the measured one, outside the stated range (below it).
By their numbers in this assay, from the lowest: compound 4; then compound 1; then compound 2; then compound 3.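

Among these compounds, this is the first single-place step: at the amide-type nitrogen whose other neighbour is the carbonyl carbon, exchanging 1-phenylethyl for 1-(thiophen-2-yl)ethyl gives, in this assay, a 2.3-fold lower number from compound 1 to compound 4 (0.37 log units; beyond the scatter). The position therefore accepts a five-membered aromatic ring with one hetero atom in place of a six-membered aromatic ring of carbon only, and the modest step runs toward a lower number, so less compound is needed for the effect. The exchange also removes the defined stereocentre of compound 1, so the step cannot be assigned to the ring alone, and no measurement is available here that explains it.

As far as these compounds go, it remains open how far the two mirror-image forms of compound 4 differ from each other in this assay, which would separate the contribution of the ring from that of the stereocentre. Also open, from the compounds shown here alone, is whether the lower number extends to other groups on this nitrogen, such as 1-(furan-2-yl)ethyl or 1-(thiophen-3-yl)ethyl, and whether it persists when the carbonyl is replaced by a thiocarbonyl.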